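This account rests on a few compounds, and the source may have more. Where it says the series, first, only, none or still open, it means among the compounds named here.

Working notes on the series in a functional assay on RAW264.7 cells (Mus musculus), with a stated time of 3 days; a higher number here means a weaker inhibitor, a lower number a stronger inhibitor. On the shared core, compound 1 `COc1cnc(-c2ccccn2)nc1N(C)C1CCCC1` gives 180 nM, compound 2 `COc1cnc(-c2ccccn2)nc1C1CCCC1` gives 1800 nM and compound 3 `COc1cnc(-c2ccccn2)nc1NC1CCCC1` gives 570 nM. Compound 3 therefore holds the middle of the three numbers, the second highest.

The next compound, compound 4 `COc1cnc(-c2ccccn2)nc1N1CCCC1`, carries pyrrolidin-1-yl in place of the cyclopentylamino of compound 3, on the aromatic carbon ortho to a methoxy group: pyrrolidin-1-yl in place of cyclopentylamino on an aromatic carbon.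

Going by the values given here, two measured steps bear most directly on this change. The first is a 3.2-fold higher number from compound 1 to compound 3 (0.50 log units; beyond the scatter), where hydrogen replaces methyl on the nitrogen, and it shows that the fully substituted nitrogen of compound 1 gives the lower number. The second is a 3.2-fold lower number from compound 2 to compound 3 (0.50 log units; beyond the scatter), where cyclopentylamino replaces cyclopentyl. Compound 4 also has a fully substituted nitrogen at this place, so a move toward compound 1 seems more likely than a move toward compound 2. Among the compounds with values here, the read-across is only partial, since no measured compound has this nitrogen inside a ring.

The expected change in this assay is a 2.3-fold lower number from compound 3 to compound 4 (0.36 log units; beyond the scatter), a modest step to a lower number. The estimated value of compound 4 is 250 nM, within an expected range of 80 nM to 750 nM.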

Compound 4, half-maximal inhibitory concentration: 150 nM
The estimate for compound 4 lay 1.7-fold (0.22 log units) above the measured number; the range from low to high includes it.
By their numbers in this assay, from the lowest: compounds 4 and 1 (each within the scatter of the next); then compound 3; then compound 2.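

In this assay, going by these compounds alone, tying the nitrogen into a ring gives a 1.2-fold lower number from compound 1 to compound 4 (0.08 log units; within the scatter), so pyrrolidin-1-yl and cyclopentyl(methyl)amino cannot be told apart here, and the cyclopentyl ring carried by all the earlier compounds is not required for a number at this level. The other two steps, a 3.8-fold lower number from compound 3 to compound 4 (0.58 log units; beyond the scatter) and a 12-fold lower number from compound 2 to compound 4 (1.08 log units; beyond the scatter), the second of them large, extend the earlier picture: in these four compounds, the two with a fully substituted nitrogen on this aromatic carbon give the two lowest numbers, and no compound shown goes against that. Nothing on hand explains why these steps take the sizes they do.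

Going by these compounds, what a piperidin-1-yl or morpholin-4-yl group would give at this place stays open, so it is unknown whether the number depends on the size of the ring or on a hetero atom within it. Also open, on these data alone, is whether pyrrolidin-1-yl keeps this number when the neighbouring methoxy group gives way to a hydrogen or an ethoxy group, or when the pyridin-2-yl group gives way to a phenyl group.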